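The source may hold more compounds than are shown below. What is called first, only, known or untested is meant among the compounds shown, and "the series" means these compounds.

Compound 2 `O=C(CCc1ccccc1)c1ccn(-c2ccc3c(c2)B(O)OC3)c1` carries a phenethyl group on the carbonyl carbon of the shared core. In an ADME assay on L929 cells (Mus musculus) for cytotoxicity, read by resazurin assay, with a stated time of 72 h (a higher number here means a weaker inhibitor, a lower number a stronger inhibitor), compound 2 reaches only the limit of > 10 ug/mL, which is a limit of the assay and not a number. Its neighbour compound 1 `O=C(c1ccn(-c2ccc3c(c2)B(O)OC3)c1)c1ccc(Cl)cc1Cl` differs by a 2,4-dichlorophenyl group on that carbonyl carbon. In this assay compound 1 likewise gives the limit of > 10 ug/mL. Within the data shown here, the step that the two limits leave unreadable from compound 1 to compound 2 therefore cannot be read, and the only evidence is the limit of > 10 ug/mL in this assay, at which 2 of the 2 values shown sit.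

Compound 3 `Cc1ccsc1C(=O)c1ccn(-c2ccc3c(c2)B(O)OC3)c1` is the next member: 3-methylthiophen-2-yl in place of phenethyl on a carbonyl carbon. No measured step bears on this change, since the one step shown is unreadable. Because of the limit of > 10 ug/mL in this assay, at which 2 of the 2 values shown sit, compound 3 is expected to give a limit as well, so the step that the limit leaves unreadable from compound 2 to compound 3 is estimated as none beyond the scatter. Compound 3 is therefore estimated at 20 ug/mL, within 8 ug/mL to 60 ug/mL.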

Compound 3, half-maximal inhibitory concentration: > 10 ug/mL
Compound 3 gave a limit, no number; the forecaster's own chance of this, stated with the estimate: 80%; the middle value is on the limit's open side.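

In this assay compound 3 gives > 10 ug/mL which is a limit of the assay and not a number. The steps among compound 1, compound 2 and compound 3 therefore cannot be read: the limit of > 10 ug/mL in this assay, at which 3 of the 3 values shown sit.

The compounds shown leave open whether any group on the carbonyl carbon of the shared core would give a measurable value in this assay and how large that value would be.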